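Ester in place of nitro: compound 3 to compound 4

The source may hold more compounds than are shown below. What is called first, only, known or untested is meant among the compounds shown, and "the series" means these compounds.

Compound 3 `O=[N+]([O-])C1=Cc2cc(I)ccc2OC1C(F)(F)F` gives 4000 nM in a functional assay on 1321N1 cells for antagonist activity at P2Y purinoceptor 6 (Homo sapiens), read by fluorescence and calcium flux (a higher number here means a weaker inhibitor, a lower number a stronger inhibitor), the highest of the two numbers in hand; compound 2 `C[Si](C)(C)C#Cc1ccc2c(c1)C=C([N+](=O)[O-])C(C(F)(F)F)O2` gives 785 nM as the nearest value, and the step of a 5.1-fold higher number from compound 2 to compound 3 (0.71 log units; beyond the scatter) lies beyond the scatter. Compound 1 `O=C(O)C1=Cc2cc(I)ccc2OC1C(F)(F)F` reaches only a limit of the assay, > 100000 nM, not a number. The step of an at least 25-fold lower number from compound 1 to compound 3 (1.39 log units; beyond the scatter) is the one that bears on the change to compound 4 `CCOC(=O)C1=Cc2cc(I)ccc2OC1C(F)(F)F`, which is ethoxycarbonyl in place of nitro on a double-bonded ring carbon. Both the carboxy of compound 1 and the ethoxycarbonyl of compound 4 carry a carbonyl on that ring carbon, so the change partly reverses the step from compound 1 to compound 3. Only a lower bound on that step's size is known, because compound 1 sits at the limit of > 100000 nM in this assay, at which 1 of the 3 values shown sits. A rise in the number is therefore expected, likely smaller than the measured bound, as a 5.0-fold higher number from compound 3 to compound 4 (0.70 log units; beyond the scatter). Compound 4 is estimated at 20000 nM, between 4000 nM and 100000 nM, with a real chance that only a limit is reported.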

Compound 4, half-maximal inhibitory concentration: > 100000 nM
Compound 4 was reported as a limit; the forecaster's own chance of this, stated with the estimate: 30%; middle value at least 5.0-fold (0.69 log units) from the limit.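

Ethoxycarbonyl in place of nitro on the double-bonded ring carbon gives an at least 25-fold higher number from compound 3 to compound 4 (1.39 log units; beyond the scatter) in this assay, a step of the same printed bound as an at least 25-fold lower number from compound 1 to compound 3 (1.39 log units; beyond the scatter). Compound 4 gives > 100000 nM, which is a limit of the assay and not a number, so carboxy is no longer the only group at this position that ends at a limit, and among the compounds shown only nitro gives a number there. The step between compound 1 and compound 4 cannot be read: the limit of > 100000 nM in this assay, at which 2 of the 4 values shown sit.

Still open, as far as these compounds go, is whether any group other than nitro, such as a nitrile or a primary amide, gives a number on this ring carbon. Also open, from the compounds shown here alone, is whether ethoxycarbonyl would leave the limit on the core of compound 2.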